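The compounds below may be only part of what the source reports. "The series", "measured", "known", "first", "only" and "open" are said of these compounds alone.

Measured so far:
compound 1 `Nc1ccc(-c2cc(=O)c3c(N)c(F)c(Cl)c(F)c3o2)cc1F` — 210 nM
compound 2 `CCCCCCCCCC(=O)OCc1c(F)c(N)c2c(=O)cc(-c3ccc(N)c(F)c3)oc2c1F` — 100 nM
compound 3 `CN(C)CCCOCc1c(F)c(N)c2c(=O)cc(-c3ccc(N)c(F)c3)oc2c1F` — a limit of the assay, > 10000 nM

In a functional assay on MCF7 cells (Homo sapiens) for cytotoxicity, read by neutral red uptake, with a stated time of 3 days (on this read-out lower numbers stand for stronger inhibition and higher numbers for weaker inhibition), compound 1 gives 210 nM, the higher of the two numbers; compound 2 gives 100 nM, a lower number. The value of compound 3 is only a limit, (the limit of > 10000 nM in this assay, at which 1 of the 3 values shown sits). Compound 4 `NCc1c(F)c(N)c2c(=O)cc(-c3ccc(N)c(F)c3)oc2c1F` differs from compound 1 by aminomethyl in place of chloro on an aromatic carbon. The step that bears on this is an at least 47-fold higher number from compound 1 to compound 3 (1.67 log units; beyond the scatter), a large loss when a nitrogen-bearing group replaces the chloro on that aromatic carbon; an at least 100-fold higher number from compound 2 to compound 3 (2.00 log units; beyond the scatter) is a large loss of the same kind. A large rise in this assay is therefore expected for compound 4. Compound 4 is estimated at 5000 nM, within 800 nM to 30000 nM, an expected step of a 24-fold higher number from compound 1 to compound 4 (1.38 log units; beyond the scatter).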

Compound 4, half-maximal inhibitory concentration: 26 nM
The estimate for compound 4 lay 190-fold (2.28 log units) above the measured number; measured number outside the range, below it.
By their numbers in this assay, from the lowest: compound 4; then compound 2; then compound 1. At a limit, above all of these: compound 3.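

In this assay, aminomethyl in place of chloro on this aromatic carbon, ortho to two fluoro groups, gives an 8.1-fold lower number from compound 1 to compound 4 (0.91 log units; beyond the scatter), so a nitrogen-bearing group here does not by itself bring a loss. On the saturated chain carbon bound to that aromatic carbon, amino in place of 3-(dimethylamino)propoxy gives an at least 380-fold lower number from compound 3 to compound 4 (2.58 log units; beyond the scatter), which ties the earlier loss to the longer group. Compound 3 stands only as a limit of the assay: the limit of > 10000 nM in this assay, at which 1 of the 4 values shown sits.

The compounds shown leave open how a hydroxymethyl group would compare with aminomethyl here. They also leave open at what length a chain ending in a primary amine would lose activity.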